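Nitrophenyl for dimethylaminophenyl on the shared core

This account rests on a few compounds, and the source may have more. Where it says the series, first, only, none or still open, it means among the compounds named here.

Measured so far:
compound 1, `CC(=O)N1N=C(c2ccc(-n3c(C)ccc3C)cc2)OC1c1ccccc1[N+](=O)[O-]`, 182000 nM
compound 2, `CC(=O)N1N=C(c2ccc(-n3c(C)ccc3C)cc2)OC1c1ccc(N(C)C)cc1`, 186000 nM
compound 3, `Cc1ccc(C)n1-c1ccc(C(=O)N/N=C/c2ccccc2)cc1`, "not determined" (no result reported)

All three compounds were tested in an ADME assay on A549 cells (Homo sapiens) for cytotoxicity, read by MTT assay, with a stated time of 72 h; a higher number here means a weaker inhibitor, a lower number a stronger inhibitor. Compound 1 gives 182000 nM and compound 2 gives 186000 nM; compound 3 gives "not determined" (no result reported), so no number is available for it. Among the compounds with values here, compound 2 thus has the higher of the two available numbers, but its only neighbour is compound 1, and the step of a 1.0-fold higher number from compound 1 to compound 2 (0.01 log units; within the scatter) is within the scatter, so the two cannot be told apart.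

Compound 4, `CC(=O)N1N=C(c2ccc(-n3c(C)ccc3C)cc2)OC1c1cccc([N+](=O)[O-])c1`, is not yet measured. It differs from compound 2 in one place: 3-nitrophenyl in place of 4-(dimethylamino)phenyl on a saturated ring carbon. Within the data shown here, the one measured step that bears on this is the step from compound 1 to compound 2, which swapped a nitrophenyl for the dimethylaminophenyl at the same saturated ring carbon and gave a 1.0-fold higher number from compound 1 to compound 2 (0.01 log units; within the scatter), a change within the scatter. Going back to a nitrophenyl, here the 3-nitrophenyl, is therefore expected to give no step beyond the scatter in this assay, an expected step of a 1.0-fold lower number from compound 2 to compound 4 (0.00 log units; within the scatter). Compound 4 is estimated at 185000 nM, with a range from 90000 nM to 370000 nM.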

Compound 4, half-maximal inhibitory concentration: 197000 nM
Beside the measured number, compound 4's estimate is 1.1-fold (0.03 log units) below it; the range from low to high includes it.
By their numbers in this assay, from the lowest: compounds 1, 2 and 4 (each within the scatter of the next).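

In this assay, putting 3-nitrophenyl in place of 4-(dimethylamino)phenyl on the saturated ring carbon gives a 1.1-fold higher number from compound 2 to compound 4 (0.02 log units; within the scatter) and so cannot be told apart from no change, while 3-nitrophenyl in place of 2-nitrophenyl gives a 1.1-fold higher number from compound 1 to compound 4 (0.03 log units; within the scatter) as the second comparison at this carbon. The earlier pair set one nitrophenyl against the dimethylaminophenyl, whereas these steps add a second nitrophenyl and show that, between 2-nitrophenyl and 3-nitrophenyl, where the nitro group sits on the phenyl ring makes no difference that this measurement can detect; all three groups at this position now read alike within the scatter. Nothing available accounts for this sameness, so it stands as an observation about these three compounds only.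

Still open, from the compounds shown here alone, is whether this position stays as unresponsive with a group of another kind, such as a phenyl ring carrying a carboxylic acid or a primary amine, or a longer alkyl chain in place of the phenyl ring. The compounds shown also all keep the same acetyl group on the ring nitrogen, so they say nothing about how a larger acyl group or a simple hydrogen there would read.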